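The source may report more compounds than this note shows. Statements on the series, on what has been measured and on what is new or still open speak of the compounds shown alone.

Three amides of one shared core have been run in a functional assay on SW-620 cells (Homo sapiens) for cytotoxicity, read by MTT assay, with a stated time of 48 h; a lower number here means a stronger inhibitor, a higher number a weaker inhibitor. Compound 1 `CCCCCCCCCCCCCCCCCCNC(=O)[C@@H](N)[C@@H](C)O` gives 21400 nM. Compound 2 `CCCCCCCCNC(=O)[C@@H](NC(=O)c1ccco1)[C@@H](C)O` gives 200000 nM, the highest number of the three; compound 3 `CCCCCCCCNC(=O)[C@@H](NC(=O)c1nccc2ccccc12)[C@@H](C)O` gives 67800 nM, and both its gap to compound 2 and that of compound 1 lie beyond the scatter. Compound 4 `C/C=C/C=C/C(=O)N[C@H](C(=O)NCCCCCCCC)[C@@H](C)O` is not yet measured. It differs from compound 2 by penta-1,3-dien-1-yl in place of furan-2-yl on a carbonyl carbon, a chain with two double bonds in place of the five-membered aromatic ring on the carbonyl carbon. Within the data shown here, no measured pair mirrors this change, so the series offers no direct precedent. The step expected from compound 2 is a modest drop in the number, a 1.8-fold lower number from compound 2 to compound 4 (0.26 log units; within the scatter), though none beyond the scatter is also plausible. Compound 4 is estimated at 110000 nM, within a range from 35000 nM to 300000 nM.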

Compound 4, half-maximal inhibitory concentration: 200000 nM
Compound 4: middle estimate off by 1.8-fold (0.26 log units), on the low side; the measured number falls inside the stated range.
By their numbers in this assay, from the lowest: compound 1; then compound 3; then compounds 2 and 4 (each within the scatter of the next).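

In this assay, penta-1,3-dien-1-yl in place of furan-2-yl on a carbonyl carbon gives no change at the digits printed from compound 2 to compound 4 (within the scatter). Among these compounds, this is the first single-place step, and it shows that the read-out does not separate the five-membered aromatic ring with its hetero atom from an open chain with two double bonds at this position. No measurement at hand explains this result. As far as these compounds go, whether a saturated pentyl chain, a longer chain, an amine or a carboxylic acid on this carbonyl carbon would shift the number remains open.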